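A few compounds are considered here, and "the series" means these few. Any claim that something is new, unique, unknown or untested is made for them only; others in the source may bear on it.

Measured compounds in an ADME assay (liver) for metabolic stability, with Liver microsome (Rattus norvegicus) as the target, read by LC-MS, using microsomes and NADPH, with stated times of 5 min and 60 min, tested at 4 uM; a lower number here means that less of the compound is left, a higher number that more of the compound is left:
compound 1, `Cc1c(OCCCCOc2ccc(C(=O)CC(C)(C)C)c(O)c2C)cccc1C(=O)O`, gives 51%;
compound 2, `Cc1c(OCCCCOc2ccc(F)c(C(=O)O)c2)ccc(C(=O)CC(C)(C)C)c1O`, gives 58%;
compound 3, `Cc1c(OCCCCOc2ccccc2C(=O)O)ccc(C(=O)CC(C)C)c1C`, gives 9%.

Compound 2 has the highest of the three numbers, but its gap to compound 1 lies within the scatter: a number 7 percentage points higher from compound 1 to compound 2 (within the scatter). Only compound 3 stands clearly apart from it.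

Compound 4, `Cc1c(OCCCCOc2ccc(F)c(C(=O)O)c2)ccc(C(=O)CC(C)C)c1O`, is not yet measured. It differs from compound 2 in one place: hydrogen in place of methyl on a saturated chain carbon bound to three saturated chain carbons. Among the measured compounds shown here, the one measured step concerns a different change, so no step bears directly on this one. Compound 3 also carries the isobutylcarbonyl group and gives the lowest number, but it differs from compound 2 in more than one place, so those two values cannot separate this change from the others. A moderate drop is nevertheless expected, a number 16 percentage points lower from compound 2 to compound 4 (beyond the scatter), with wide uncertainty. Compound 4 is estimated at 42% in this assay, between 18% and 66%.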

Compound 4, percent of the compound remaining: 59%
For compound 4 the middle estimate is 17 percentage points below the measured one; measured number inside the range.
By their numbers in this assay, from the lowest: compound 3; then compounds 1, 2 and 4 (each within the scatter of the next).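

In this assay, the change from neopentylcarbonyl to isobutylcarbonyl gives a number 1 percentage points higher from compound 2 to compound 4 (within the scatter). On this saturated chain carbon, then, the methyl can be replaced by hydrogen with no change that stands out from the usual variation between repeats. No available measurement explains this result.

From the compounds shown here alone, whether the number would hold with a longer chain, a cyclopropyl ring or an amine at this place remains open. So does whether the same swap would read alike on a different core.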